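Fluoro for chloro: the step from compound 1 to compound 3

The source may report more compounds than this note shows. Statements on the series, on what has been measured and on what is new or still open speak of the compounds shown alone.

Measured so far:
compound 1, `Cc1nc2c([nH]1)C(=O)/C(=N/c1ccc(Cl)cc1)C(Cl)=C2O`, gives 800 nM in a functional assay on HUVEC cells (Homo sapiens) for antiproliferative activity; on this read-out higher numbers stand for weaker inhibition and lower numbers for stronger inhibition
compound 2, `Cc1nc2c([nH]1)C(=O)/C(=N/c1ccc(F)cc1F)C(Cl)=C2O`, gives 1000 nM in this assay

Compound 1 carries the lowest of the two numbers, and the nearest value, that of compound 2, lies within the usual scatter, so the two cannot be told apart on these data. Within the data shown here, no step between two measured compounds that differ in one place is available. Compound 3, `Cc1nc2c([nH]1)C(=O)/C(=N/c1ccc(F)cc1)C(Cl)=C2O`, awaits measurement; it differs from compound 1 by fluoro in place of chloro on an aromatic carbon. Among the measured compounds shown here, nothing measured here reports the size of such a swap, and the only comparison, compound 1 against compound 2, is itself within the scatter. The step from compound 1 to compound 3 is therefore expected to be small, a 1.4-fold higher number from compound 1 to compound 3 (0.14 log units; within the scatter), not clearly beyond the scatter, with a slight lean toward a higher number. Compound 3 is estimated at 1100 nM, with a range from 500 nM to 2500 nM.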

Compound 3, half-maximal inhibitory concentration: 1000 nM
The estimate for compound 3 lay 1.1-fold (0.04 log units) above the measured number; measured number inside the range.
By their numbers in this assay, from the lowest: compounds 1, 2 and 3 (each within the scatter of the next).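

In this assay, among these compounds, fluoro in place of chloro on an aromatic carbon, para to a large group, gives a 1.3-fold higher number from compound 1 to compound 3 (0.10 log units; within the scatter), the first direct reading at this position, and on these data the two halogens cannot be told apart there. Hydrogen in place of fluoro on an aromatic carbon gives no change at the digits printed from compound 2 to compound 3 (within the scatter), so the extra fluoro of compound 2 leaves no readable mark on this number. No supporting measurement bears on these two steps.

Every compound shown carries a halogen at this position, so it remains open whether an amine, a methoxy group or a carboxylic acid there would move the number beyond the scatter. Also open, going by these compounds, is whether the chloro on the shared core can give way to hydrogen or a methyl group.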